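The source may report more compounds than this note shows. Statements on the series, on what has been measured and on what is new or still open speak of the compounds shown alone.

Measured compounds:
compound 1 `Nc1ccccc1NC(=O)c1ccc(CSC(=S)N2CCN(c3ccc(Cl)cc3)CC2)cc1`: 15%
compound 2 `CCN(Cc1ccncc1)C(=S)SCc1ccc(C(=O)Nc2ccccc2N)cc1`: 71.6%

In a functional assay on MGC-803 cells (Homo sapiens) for antiproliferative activity, read by CCK-8 assay, with a stated time of 72 h, tested at 2 uM (a lower number here means a weaker effect, a higher number a stronger effect of the compound at the concentration tested), compound 1 gives 15%, the lower of the two numbers shown. Compound 2 `CCN(Cc1ccncc1)C(=S)SCc1ccc(C(=O)Nc2ccccc2N)cc1` gives 71.6% in this assay, a number that lies beyond the usual scatter above the value of compound 1. The two compounds share the same benzamide part but differ in several places at once, so their gap cannot be tied to any single change.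

Compound 3 `Nc1ccccc1NC(=O)c1ccc(CSC(=S)N2CCN(c3ncccn3)CC2)cc1` has not yet been measured in this assay. It differs from compound 1 in one place: pyrimidin-2-yl in place of 4-chlorophenyl on an amine nitrogen in a ring. For the measured compounds named here, no pair of measured compounds differs in this way, so there is no measured step to lean on for the size of the change.

Without such a guide, the step of a number 5 percentage points higher from compound 1 to compound 3 (within the scatter) is expected to stay small, near or within the usual scatter, with no firm direction. Compound 3 is therefore estimated at 20% in this assay, with a range from 5% to 45%.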

Compound 3, a percentage reported as inhibition, at one concentration (the size of the read-out at that concentration, not a potency): 28.4%
For compound 3 the middle estimate is 8.4 percentage points below the measured one; measured number inside the range.
By their numbers in this assay, from the lowest: compound 1; then compound 3; then compound 2.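

In this assay, for the compounds shown here, the exchange of 4-chlorophenyl for pyrimidin-2-yl gives a number 13.4 percentage points higher from compound 1 to compound 3 (beyond the scatter), the first measured step at this amine nitrogen in a ring. It shows that the position accepts an aromatic ring with 2 hetero atoms and 2 hydrogen-bond acceptors in place of a carbon-only ring with no acceptors, and that the read-out rises modestly with this exchange rather than falling. No measurement shown explains the step, and it cannot be assigned either to the ring nitrogens that enter or to the chlorine that leaves.

From the compounds shown here alone, what remains open is which part of the exchange carries the step: a plain phenyl on the same nitrogen would separate the loss of the chlorine from the entry of the ring nitrogens, and a pyridin-2-yl would show whether one ring nitrogen gives the same result as two. Also open, going by these compounds, is whether a non-aromatic group at this place, such as a methyl or a longer alkyl chain, would keep the read-out, or whether an aromatic ring is needed there at all.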